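The compounds below may be only part of what the source reports. "The series", "measured", "known", "first", "only" and "open" are said of these compounds alone.

Series notes. Compound 1 `Cc1cc(-c2c(F)cc3c(=O)c(Cc4ccc(Cl)cc4)cn(C4CC4)c3c2F)cc(C)n1` and compound 2 `Cc1cc(-c2c(F)cc3c(=O)c(C(=O)O)cn(C4CC4)c3c2F)cc(C)n1` share one core and differ at a single aromatic carbon. In a functional assay on P388 cells (Mus musculus) for cytotoxicity (on this read-out lower numbers stand for stronger inhibition and higher numbers for weaker inhibition), compound 1 gives 20000 nM and compound 2 gives 29000 nM. For the measured compounds named here, the only measured step is a 1.5-fold higher number from compound 1 to compound 2 (0.16 log units; within the scatter). Among the two numbers compound 2 has the highest, with compound 1 nearest. Compound 3 `COc1ccc(Cc2cn(C3CC3)c3c(F)c(-c4cc(C)nc(C)c4)c(F)cc3c2=O)cc1` is not yet measured; it differs from compound 2 by 4-methoxybenzyl in place of carboxy on an aromatic carbon. Going by the values given here, the one measured step bears on this change, since it exchanges the same carboxy for a 4-chlorobenzyl, another benzyl group, and that step stayed within the scatter. No step beyond the scatter is therefore expected in this assay, and compound 3 is expected to sit near compound 1. Compound 3 is estimated at 20000 nM with a range of 8000 nM to 50000 nM. The step expected from this is a 1.5-fold lower number from compound 2 to compound 3 (0.16 log units; within the scatter).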

Compound 3, half-maximal inhibitory concentration: 21000 nM
Beside the measured number, compound 3's estimate is 1.1-fold (0.02 log units) below it; low and high end bracket the measured number.
By their numbers in this assay, from the lowest: compounds 1, 3 and 2 (each within the scatter of the next).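

In this assay, the step from carboxy to 4-methoxybenzyl is a 1.4-fold lower number from compound 2 to compound 3 (0.14 log units; within the scatter), so a second benzyl group on this aromatic carbon also stays within the scatter of the carboxy compound. Methoxy in place of chloro on the benzyl ring, the first change read on that ring itself, is a 1.1-fold higher number from compound 1 to compound 3 (0.02 log units; within the scatter), which shows that this exchange does not separate compound 1 from compound 3 on this read-out. No measurement at hand offers a reason for this lack of separation.

Carboxy and the two substituted benzyl groups therefore give no step beyond the scatter at this position, and whether any group placed here can do so remains open. An amine or a longer alkyl chain on this aromatic carbon, or a hydroxy group in place of methoxy on the benzyl ring, would test this.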